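A few compounds are considered here, and "the series" means these few. Any claim that something is new, unique, unknown or untested is made for them only; others in the source may bear on it.

Compound 1 `Cc1cccc(C)c1NC(=O)/C=C/C(=O)N1C/C(=C\c2ccccc2)C(=O)/C(=C/c2ccccc2)C1`: 6600 nM in a functional assay on Molt4/C8 cells (Homo sapiens) for cytotoxicity; a lower number here means a stronger inhibitor, a higher number a weaker inhibitor. Compound 2 `CC(=O)c1ccc(NC(=O)/C=C/C(=O)N2C/C(=C\c3ccccc3)C(=O)/C(=C/c3ccccc3)C2)cc1`: 1400 nM. Compound 3 `COc1ccc(NC(=O)/C=C/C(=O)N2C/C(=C\c3ccccc3)C(=O)/C(=C/c3ccccc3)C2)cc1`: 1100 nM.

Compound 3 has the lowest of the three numbers in this assay; compound 2 lies close to it, a gap within the scatter (a 1.3-fold lower number from compound 2 to compound 3 (0.10 log units; within the scatter)), while compound 1 sits well apart (a 6.0-fold lower number from compound 1 to compound 3 (0.78 log units; beyond the scatter)). Compound 4 `O=C(/C=C/C(=O)N1C/C(=C\c2ccccc2)C(=O)/C(=C/c2ccccc2)C1)Nc1ccccc1` differs from compound 3 by hydrogen in place of methoxy on an aromatic carbon. The step that bears on this most is the exchange of one group for another on that same aromatic carbon, a 1.3-fold lower number from compound 2 to compound 3 (0.10 log units; within the scatter), which stayed within the scatter; the larger steps of a 4.7-fold lower number from compound 1 to compound 2 (0.67 log units; beyond the scatter) and a 6.0-fold lower number from compound 1 to compound 3 (0.78 log units; beyond the scatter) swapped the whole aryl group and give no direct guide. For compound 4 a step within the scatter is therefore expected, a 1.4-fold higher number from compound 3 to compound 4 (0.13 log units; within the scatter). Compound 4 is expected to give 1500 nM, between 700 nM and 3500 nM.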

Compound 4, half-maximal inhibitory concentration: 520 nM
The estimate for compound 4 lay 2.9-fold (0.46 log units) above the measured number; measured number outside the range, below it.
By their numbers in this assay, from the lowest: compound 4; then compounds 3 and 2 (each within the scatter of the next); then compound 1.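

In this assay compound 4, with its unsubstituted phenyl, is the strongest inhibitor of the four: hydrogen on this aromatic carbon beats both methoxy, a 2.1-fold lower number from compound 3 to compound 4 (0.33 log units; beyond the scatter), and acetyl, a 2.7-fold lower number from compound 2 to compound 4 (0.43 log units; beyond the scatter), although those two groups do not separate from each other. Among the compounds shown here, replacing 2,6-dimethylphenyl with phenyl gives the largest step so far, a 13-fold lower number from compound 1 to compound 4 (1.10 log units; beyond the scatter). Nothing shown explains why hydrogen does better here.

On these data alone, it remains open whether a small atom such as fluorine, or an amine or a carboxylic acid, on this same carbon would match hydrogen.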